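Swapping Hydroxy for Chloro on an Aromatic Carbon

The source may hold more compounds than are shown below. What is called first, only, known or untested is meant among the compounds shown, and "the series" means these compounds.

Measured so far in a functional assay on A549 cells (Homo sapiens) for antiproliferative activity, read by MTT assay, with a stated time of 48 h; a higher number here means a weaker inhibitor of growth, a lower number a stronger inhibitor of growth
- compound 1 `COC(=O)N1N=C(c2ccc(OC)cc2)CC1c1cc(OC)c(OC)c(OC)c1` gives 3400 nM
- compound 2 `COC(=O)N1N=C(c2cccc(O)c2)CC1c1cc(OC)c(OC)c(OC)c1` gives 3170 nM
- compound 3 `CCOC(=O)N1N=C(c2cccc(O)c2)CC1c1cc(OC)c(OC)c(OC)c1` gives 5120 nM

On these numbers, compound 2 cannot be told apart from compound 1 or compound 3, since all its measured steps stay within the scatter. Compound 4 `COC(=O)N1N=C(c2cccc(Cl)c2)CC1c1cc(OC)c(OC)c(OC)c1` carries chloro in place of hydroxy on an aromatic carbon. The nearest evidence is a 1.1-fold lower number from compound 1 to compound 2 (0.03 log units; within the scatter), a change on the same aromatic ring. The other measured step, a 1.6-fold higher number from compound 2 to compound 3 (0.21 log units; within the scatter), lies elsewhere in the molecule and bears on this change only weakly. Going by the values given here, no measured compound shows a direct swap of hydroxy for chloro, so the expectation is loose, with no step beyond the scatter and no favoured direction. The expected change is a 1.0-fold higher number from compound 2 to compound 4 (0.00 log units; within the scatter) in size. For compound 4 the estimated value is 3200 nM, with an expected range from 1200 nM to 8500 nM.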

Compound 4, concentration for 50% growth inhibition: 340 nM
Estimate against measurement, compound 4: 9.4-fold (0.97 log units) above; the measured number lies below the stated range.
By their numbers in this assay, from the lowest: compound 4; then compounds 2, 1 and 3 (each within the scatter of the next).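

In this assay, going by these compounds alone, chloro on this aromatic carbon gives the first change beyond the scatter: a 9.3-fold lower number from compound 2 to compound 4 (0.97 log units; beyond the scatter) and a 10-fold lower number from compound 1 to compound 4 (1.00 log units; beyond the scatter) show that the group on this ring matters, although the earlier swap between 3-hydroxyphenyl and 4-methoxyphenyl showed no such effect. Chloro counts no hydrogen-bond donor or acceptor, whereas hydroxy counts one of each, but this count alone does not establish the reason for the drop. Nothing measured here explains the result. As far as these compounds go, whether bromo, methyl or an amine in the same place would match chloro remains open. So does whether chloro would give a similar step alongside the ethyl ester of compound 3.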